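Shorter alkyl at the ring nitrogen: compound 3

A few compounds are considered here, and "the series" means these few. Any claim that something is new, unique, unknown or untested is made for them only; others in the source may bear on it.

Compound 1 `COc1ccc(-c2cc(=O)n(Cc3cccnc3)nc2-c2ccc(OC)cc2)cc1` carries a pyridin-3-yl on the saturated chain carbon bound to the aromatic nitrogen; in a functional assay on HL-60 cells (Homo sapiens) for inhibition (on this read-out higher numbers stand for weaker inhibition and lower numbers for stronger inhibition), compound 1 gives 430 nM. Compound 2 `COc1ccc(-c2cc(=O)n(CC(C)C)nc2-c2ccc(OC)cc2)cc1` in this assay gives only a limit, > 100000 nM. Within the data shown here, the one measured step, an at least 230-fold higher number from compound 1 to compound 2 (2.36 log units; beyond the scatter), runs into (the limit of > 100000 nM in this assay, at which 1 of the 2 values shown sits). Compound 3 `COc1ccc(-c2cc(=O)n(C(C)C)nc2-c2ccc(OC)cc2)cc1` differs by isopropyl in place of isobutyl on an aromatic nitrogen. Among the measured compounds shown here, with compound 2 at the limit, no measured step of comparable kind exists; the change is expected to give no step beyond the scatter, a number no higher from compound 2 to compound 3 (the limit leaves the size open). Compound 3 is therefore estimated at 100000 nM, within 20000 nM to 400000 nM, most likely again reported as a limit.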

Compound 3, half-maximal inhibitory concentration: 1320 nM
Beside the measured number, compound 3's estimate is 76-fold (1.88 log units) above it; the measured number lies below the stated range.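

At this nitrogen, the pyridin-3-yl is not required for a measurable number in this assay: replacing (pyridin-3-yl)methyl with isopropyl gives only a 3.1-fold higher number from compound 1 to compound 3 (0.49 log units; beyond the scatter). Small alkyl groups do not behave alike here, as isopropyl in place of isobutyl gives an at least 75-fold lower number from compound 2 to compound 3 (1.87 log units; beyond the scatter). The value of compound 2 is a limit, so this step has no upper size: the limit of > 100000 nM in this assay, at which 1 of the 3 values shown sits.

Open, from the compounds shown here alone, is whether a methyl group, a longer chain or a chain ending in an amine would stay near compound 3 or reach the limit of compound 2.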